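Chromone dithiocarbamates on breast cancer cells: one amine swap

A few compounds are considered here, and "the series" means these few. Any claim that something is new, unique, unknown or untested is made for them only; others in the source may bear on it.

Of the compounds shown here, three have been tested in a functional assay on MCF7 cells (Homo sapiens) for antiproliferative activity, read by MTT assay, with a stated time of 72 h; a lower number here means a stronger inhibitor, a higher number a weaker inhibitor. Compound 3, `CC(C)N(C(=S)SCc1cc(=O)c2ccc(Cl)cc2o1)C(C)C`, carries a diisopropylamino group on a thiocarbonyl carbon. In this assay compound 3 gives > 25000 nM, which is a limit of the assay rather than a number. Compound 1, `O=c1cc(CSC(=S)N2CCCCC2)oc2cc(Cl)ccc12`, shares the core of compound 3 and differs from it by piperidin-1-yl in place of diisopropylamino on a thiocarbonyl carbon. In this assay compound 1 gives > 25000 nM, again a limit. The step that the two limits leave unreadable from compound 3 to compound 1 therefore cannot be read, because of the limit of > 25000 nM in this assay, at which 3 of the 3 values shown sit.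

Compound 2, `COc1ccc2oc(CSC(=S)N(C(C)C)C(C)C)cc(=O)c2c1`, keeps the diisopropylamino group but sits on a different core; the difference between the two cores is not broken down here. In this assay compound 2 gives > 25000 nM, once more a limit.

Compound 4, `COc1ccc2oc(CSC(=S)N3CCCCC3)cc(=O)c2c1`, has not yet been measured. It differs from compound 2 by piperidin-1-yl in place of diisopropylamino on a thiocarbonyl carbon, the same change already made from compound 3 to compound 1. Since that earlier change moved between two limits, nothing about its size can be taken from it, and all three measured compounds rest at the limit. The step from compound 2 to compound 4 is therefore expected to be about a step that the limit leaves unreadable from compound 2 to compound 4, with wide uncertainty. Compound 4 is expected to give roughly 40000 nM, most likely again reported only as a limit, within a range from 12000 nM to 150000 nM.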

Compound 4, half-maximal inhibitory concentration: 10000 nM
Compound 4: the middle estimate sits 4.0-fold (0.60 log units) above what was measured, outside the stated range (below it).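

On the core of compound 2, piperidin-1-yl in place of diisopropylamino on a thiocarbonyl carbon gives an at least 2.5-fold lower number from compound 2 to compound 4 (0.39 log units; beyond the scatter) in this assay, so this one pair shows that the swap can matter in this series. Going by these compounds, compound 2 gives > 25000 nM, which is a limit and not a number, so the printed size is only the smallest the step can be and its true size remains unknown. The result does not show that the change carries from one core to another, because the matching step on the core of compound 3 cannot be read and so offers nothing to compare with: the limit of > 25000 nM in this assay, at which 3 of the 4 values shown sit.

What the compounds shown leave open is whether the gain belongs to the piperidine ring in particular or would also appear with another amine on the same thiocarbonyl carbon, such as morpholin-4-yl, pyrrolidin-1-yl or plain dimethylamino. Only compound 4 gives a number rather than a limit, so a second piperidin-1-yl compound on a further core, for instance one bearing a fluorine atom, would be needed before any rule about this swap could be claimed.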